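The source may hold more compounds than are shown below. What is called first, only, known or untested is meant among the compounds shown, and "the series" means these compounds.

Compound 3 `C=C(Br)C(=O)Nc1ccc(/C=C2\SC(=O)N(Cc3cccc(Cl)c3)C2=O)cc1` gives 8900 nM in a functional assay on HeLa cells (Homo sapiens) for cytotoxicity, read by cell counting, with a stated time of 4 days; on this read-out higher numbers stand for weaker inhibition and lower numbers for stronger inhibition. Among the three numbers in this assay it stands second highest. Among the compounds with values here, its nearest neighbour is compound 1 `C=C(Br)C(=O)Nc1ccc(/C=C2\SC(=O)N(Cc3cccc(F)c3)C2=O)cc1`, which gives 5900 nM, a result within the scatter of the one for compound 3. Furthest from it is compound 2 `Nc1ccc(/C=C2\SC(=O)N(Cc3ccc(Cl)cc3)C2=O)cc1`, which gives 77000 nM and differs from compound 3 in more than one place, so its two values are all that can be said of that pair.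

The step to compound 4 `C=C(Br)C(=O)Nc1ccc(/C=C2\SC(=O)N(Cc3ccc(C)cc3)C2=O)cc1` is 4-methylphenyl in place of 3-chlorophenyl on a saturated chain carbon bound to an amide-type nitrogen in a ring. Within the data shown here, the one measured step that touches the same part of the shared core is a 1.5-fold higher number from compound 1 to compound 3 (0.18 log units; within the scatter), a halogen exchange that stayed within the scatter. Among the measured compounds shown here, no measured step exchanges a chloro for a methyl or shifts a group on that ring, so the only guide is that this position has so far tolerated change. Compound 4 is therefore expected to sit close to compound 3, with an estimated step of a 1.1-fold lower number from compound 3 to compound 4 (0.05 log units; within the scatter). The estimate for compound 4 is 8000 nM, with a range from 3500 nM to 20000 nM.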

Compound 4, half-maximal inhibitory concentration: 8900 nM
Compound 4: the middle estimate sits 1.1-fold (0.05 log units) below what was measured, and the stated range covers the measured number.
By their numbers in this assay, from the lowest: compounds 1, 3 and 4 (each within the scatter of the next); then compound 2.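

Replacing 3-chlorophenyl with 4-methylphenyl on a saturated chain carbon bound to an amide-type nitrogen in a ring leaves the read-out in this assay unmoved (no change at the digits printed from compound 3 to compound 4 (within the scatter)), and the exchange from 3-fluorophenyl to the same group also stays within the scatter (a 1.5-fold higher number from compound 1 to compound 4 (0.18 log units; within the scatter)). Until now, this part of the molecule had only been probed by exchanging one halogen for another, whereas compound 4 shows that an aromatic ring carrying no halogen reads alike with compounds 1 and 3. Because the substituent and its ring position change together in these steps, the two changes cannot be told apart.

The compounds shown leave open whether a 3-methylphenyl or 4-chlorophenyl group would read alike. They also leave open what an amine or a carboxylic acid on this ring, or a longer chain in place of the benzyl carbon, would do. No evidence at hand accounts for these values.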